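A few compounds are considered here, and "the series" means these few. Any claim that something is new, unique, unknown or untested is made for them only; others in the source may bear on it.

Measured in a functional assay on DU-145 cells (Homo sapiens) for inhibition, read by trypan blue exclusion, with a stated time of 72 h; a higher number here means a weaker inhibitor, a lower number a stronger inhibitor:
- compound 1 `Cn1c(=O)c(C(=O)Nc2ccc(F)cc2F)cc2cnc(Nc3ccc4[nH]ccc4c3)nc21`: 5000 nM
- compound 2 `Cn1c(=O)c(S(=O)(=O)Cc2ccc(F)cc2)cc2cnc(Nc3ccc4[nH]ccc4c3)nc21`: 30000 nM
- compound 3 `Cn1c(=O)c(S(=O)(=O)c2ccc(F)cc2)cc2cnc(Nc3ccc4[nH]ccc4c3)nc21`: 300 nM

The lowest number of the three belongs to compound 3, at 300 nM. The measured steps leading to it are large: a 17-fold lower number from compound 1 to compound 3 (1.22 log units; beyond the scatter), and a 100-fold lower number from compound 2 to compound 3 (2.00 log units; beyond the scatter). The remaining step, a 6.0-fold higher number from compound 1 to compound 2 (0.78 log units; beyond the scatter), is modest.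

The next compound, compound 4 `Cn1c(=O)c(S(=O)(=O)c2ccc(F)cc2)cc2cnc(Nc3cccc4[nH]ccc34)nc21`, has 1H-indol-4-yl in place of 1H-indol-5-yl on a nitrogen on an aromatic ring. Going by the values given here, no measured step bears directly on this change. All three concern the group on an aromatic carbon or on the sulfonyl sulfur, and all three compounds carry 1H-indol-5-yl. Among the compounds with values here, those steps show only that a single change in this small set can move the number well beyond the scatter, as in a 100-fold lower number from compound 2 to compound 3 (2.00 log units; beyond the scatter). They give no direction for the new change. The expectation leans towards a higher number in this assay, but only weakly, as compound 3 at 300 nM is the lowest so far. The expected step is modest: a 3.0-fold higher number from compound 3 to compound 4 (0.48 log units; beyond the scatter). The estimate for compound 4 is 900 nM, with an expected range from 200 nM to 5000 nM.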

Compound 4, half-maximal inhibitory concentration: 750 nM
For compound 4 the middle estimate is 1.2-fold (0.08 log units) above the measured one, and the stated range covers the measured number.
By their numbers in this assay, from the lowest: compound 3; then compound 4; then compound 1; then compound 2.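

Going by these compounds alone, the move from 1H-indol-5-yl to 1H-indol-4-yl on the amino nitrogen gives, in this assay, a 2.5-fold higher number from compound 3 to compound 4 (0.40 log units; beyond the scatter), and this is the first reading of this position, as all the earlier compounds carried 1H-indol-5-yl. The two groups have the same atoms and the same counts of rings, donors and acceptors and differ only in how they are joined, so the way the group is attached matters on its own, though the step is much smaller than the change on the sulfonyl sulfur, a 100-fold lower number from compound 2 to compound 3 (2.00 log units; beyond the scatter). Nothing in the data accounts for the difference between these two attachments.

From the compounds shown here alone, the position therefore rests on a single pair, with the (4-fluorophenyl)sulfonyl group held constant, and whether the same step would appear with the (2,4-difluorophenyl)carbamoyl group of compound 1 remains open. Also open, going by these compounds, is how the number would respond at this position to 1H-indol-6-yl, to a methyl group on the ring nitrogen of the 1H-indol-4-yl group, or to a phenyl ring carrying an amine or a carboxylic acid.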